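The source may hold more compounds than are shown below. What is called first, only, known or untested is meant among the compounds shown, and "the series" means these compounds.

Within the data shown here, compound 1 `COc1cc(/C=N/c2c(C#N)ncn2-c2ccc(F)cc2)cc(OC)c1OC` is one of only two compounds measured so far. In a functional assay on HT-29 cells (Homo sapiens) for antiproliferative activity, read by MTT assay, with a stated time of 48 h (on this read-out higher numbers stand for weaker inhibition and lower numbers for stronger inhibition), compound 1 gives 13700 nM, and compound 2 `COc1ccc(/C=N/c2c(C#N)ncn2-c2ccc(F)cc2)cc1OC` gives 7230 nM. The step of a 1.9-fold lower number from compound 1 to compound 2 (0.28 log units; within the scatter) lies within the scatter and concerns hydrogen in place of methoxy on an aromatic carbon. Compound 3 `COc1cc(/C=N/c2c(C#N)ncn2Cc2ccc(F)cc2)cc(OC)c1OC` differs from compound 1 by 4-fluorobenzyl in place of 4-fluorophenyl on an aromatic nitrogen. Among the measured compounds shown here, no measured step bears on a change at this ring nitrogen, so nothing in the numbers points in either direction. Compound 3 is therefore expected to stay close to compound 1, a step of a 1.1-fold lower number from compound 1 to compound 3 (0.06 log units; within the scatter). The estimate for compound 3 is 12000 nM, with a range from 3000 nM to 50000 nM.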

Compound 3, half-maximal inhibitory concentration: 16500 nM
Beside the measured number, compound 3's estimate is 1.4-fold (0.14 log units) below it; measured number inside the range.
By their numbers in this assay, from the lowest: compounds 2, 1 and 3 (each within the scatter of the next, the first and the last beyond it).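

At the aromatic nitrogen of the shared core, 4-fluorobenzyl in place of 4-fluorophenyl gives, in this assay, a 1.2-fold higher number from compound 1 to compound 3 (0.08 log units; within the scatter). Among these compounds, this is the first reading at this position, and it shows that the two groups cannot be told apart here. Nothing available accounts for this result. On these data alone, whether this nitrogen would read the same with a longer chain ending in an amine or a carboxylic acid remains open. Also open, as far as these compounds go, is whether hydrogen in place of methoxy gives a similar step when 4-fluorobenzyl is present.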